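The compounds below may be only part of what the source reports. "The series", "measured", "known", "first", "only" and "open" are said of these compounds alone.

The series starts from compound 1 `N#CC1=C(N)Oc2c(N)cc3nc4ccccc4nc3c2C12C(=O)N(Cc1cnnn1-c1ccc(F)cc1)c1ccccc12`. In a functional assay on HepG2 cells (Homo sapiens) for antiproliferative activity, read by MTT assay, with a stated time of 48 h (a lower number here means a stronger inhibitor, a higher number a weaker inhibitor), compound 1 reaches only a limit of the assay, > 50000 nM. Compound 2 `Cc1ccc(-n2nncc2CN2C(=O)C3(C(C#N)=C(N)Oc4c(N)cc5nc6ccccc6nc5c43)c3ccccc32)cc1C` carries 3,4-dimethylphenyl in place of 4-fluorophenyl on an aromatic nitrogen. In this assay compound 2 likewise gives only a limit, > 50000 nM. The step that the two limits leave unreadable from compound 1 to compound 2 thus cannot be read, since both values sit at the limit of > 50000 nM in this assay, at which 2 of the 2 values shown sit. Compound 3 `CCc1cccc(C)c1-n1nncc1CN1C(=O)C2(C(C#N)=C(N)Oc3c(N)cc4nc5ccccc5nc4c32)c2ccccc21` differs from compound 2 by 2-ethyl-6-methylphenyl in place of 3,4-dimethylphenyl on an aromatic nitrogen. Going by the values given here, no measured step in this set has a readable size, so there is no ground to expect compound 3 to move beyond the scatter in either direction, and the one step that bears on it, from compound 1 to compound 2, gives no number. Compound 3 is therefore expected to sit again at the limit, with an estimated 60000 nM, a range of 15000 nM to 200000 nM, and an estimated step that the limit leaves unreadable from compound 2 to compound 3.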

Compound 3, half-maximal inhibitory concentration: > 50000 nM
Compound 3 gave a limit, no number; the forecaster's own chance of this, stated with the estimate: 80%; the middle value lies beyond the limit too.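

Going by these compounds alone, no step among compound 1, compound 2 and compound 3 can be read, since each value in this assay is a limit and not a number: the limit of > 50000 nM in this assay, at which 3 of the 3 values shown sit. These compounds leave open whether the group on the aromatic nitrogen changes activity in this assay at all.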